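This account rests on a few compounds, and the source may have more. Where it says the series, first, only, none or still open, it means among the compounds named here.

In a functional assay on THP-1 cells (Homo sapiens) for cytotoxicity, read by MTT assay, with a stated time of 48 h (a lower number here means a stronger inhibitor, a higher number a weaker inhibitor), compound 1 `C=C/C(C)=C\CC/C(C)=C/c1cc(C(=O)O)co1` gives 56600 nM and compound 2 `C=C/C(C)=C\CC/C(C)=C/c1cc(C(=O)OC)co1` gives 51400 nM with the two values within the scatter of each other. Compound 3 `C=C/C(C)=C\CC/C(C)=C/c1cc(C(=O)Nc2ccc(C)cc2)co1` differs from compound 2 by (4-methylphenyl)amino in place of methoxy on a carbonyl carbon in a single change: (4-methylphenyl)amino in place of methoxy on a carbonyl carbon. Within the data shown here, the only measured step at that carbonyl carbon is a 1.1-fold lower number from compound 1 to compound 2 (0.04 log units; within the scatter) and it is small. Among the measured compounds shown here, no measured compound carries the entering ring, so the expectation in this assay is no step beyond the scatter, in either direction. The expected step is a 1.3-fold lower number from compound 2 to compound 3 (0.11 log units; within the scatter) and its uncertainty is wide. Compound 3 is estimated at 40000 nM with an expected range of 13000 nM to 100000 nM on this single step.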

Compound 3, half-maximal inhibitory concentration: 60400 nM
Beside the measured number, compound 3's estimate is 1.5-fold (0.18 log units) below it; the measured number falls inside the stated range.
By their numbers in this assay, from the lowest: compounds 2, 1 and 3 (each within the scatter of the next).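

In this assay, placing an aromatic ring on the carbonyl carbon through (4-methylphenyl)amino leaves the number within the scatter, with a 1.2-fold higher number from compound 2 to compound 3 (0.07 log units; within the scatter) from the methyl ester and a 1.1-fold higher number from compound 1 to compound 3 (0.03 log units; within the scatter) from the acid. Hydroxy, methoxy and (4-methylphenyl)amino on this carbon therefore give values that cannot be separated, even though the entering group has 8 heavy atoms and an amide hydrogen. No supporting evidence bears on this result.

Still open, from the compounds shown here alone, is whether an aliphatic amine on the carbonyl carbon, such as morpholine, would give a step beyond the scatter. The same question stands for a change in the shared core away from that carbon.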